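The source may report more compounds than this note shows. Statements on the series, on what has been measured and on what is new or still open speak of the compounds shown alone.

Compound 2 `COc1ccc([C@H]2CC(=O)N(c3cccc(C)c3)C2)cc1OC1CCCC1` was examined in a functional assay on HEK293 cells (Homo sapiens) for cytotoxicity; on this read-out higher numbers stand for lower toxicity in this test and lower numbers for higher toxicity in this test. In this assay compound 2 gives > 10000 nM, which is a limit of the test rather than a number. Compound 1 `COc1ccc([C@H]2CC(=O)N(Cc3cccc(N)c3)C2)cc1OC1CCCC1` in this assay gives > 10000 nM, also a limit. Compound 3 `COc1ccc([C@H]2CC(=O)N(c3ccc(C)cc3)C2)cc1OC1CCCC1` in this assay gives > 10000 nM, again a limit. All three measured compounds therefore share (the limit of > 10000 nM in this assay, at which 3 of the 3 values shown sit), so the steps a step that the two limits leave unreadable from compound 1 to compound 2, a step that the two limits leave unreadable from compound 1 to compound 3 and a step that the two limits leave unreadable from compound 2 to compound 3 cannot be sized in either direction. Compound 4 `COc1ccc([C@H]2CC(=O)N(c3cccc(NS(=O)(=O)c4ccc(F)cc4)c3)C2)cc1OC1CCCC1` differs from compound 2 by ((4-fluorophenyl)sulfonyl)amino in place of methyl on an aromatic carbon. No measured step shows what such a change does in this assay, and the shared core has so far shown no toxicity within the range of the test. Compound 4 is therefore expected to remain near the limit, an estimated step that the limit leaves unreadable from compound 2 to compound 4. The estimate for compound 4 in this assay is 15000 nM, expected to fall between 5000 nM and 50000 nM.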

Compound 4, half-maximal cytotoxic concentration: > 10000 nM
Compound 4 ended at the assay's limit; the forecaster's own chance of this, stated with the estimate: 80%; the middle value is on the limit's open side.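

Within the data shown here, compound 2 and compound 4 both stop at a limit of the test in this assay, so no step between them can be read. The compounds shown leave open what concentration, if any, would harm these cells.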